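Amino Added to a Potent Furan Nucleoside Core

The source may report more compounds than this note shows. Statements on the series, on what has been measured and on what is new or still open speak of the compounds shown alone.

Of the compounds shown here, three sharing one nucleoside core have been tested in a functional assay on HCT-116 cells (Homo sapiens), read by MTT assay, with a stated time of 72 h; on this read-out lower numbers stand for stronger inhibition and higher numbers for weaker inhibition. Compound 1 `COc1ncnc2c1c(-c1ccccc1)cn2[C@@H]1O[C@H](CO)[C@@H](O)[C@H]1O` carries a phenyl group on an aromatic carbon of the core. In this assay compound 1 gives only a limit of the assay, > 20000 nM. Compound 2 `COc1ncnc2c1c(-c1ccco1)cn2[C@@H]1O[C@H](CO)[C@@H](O)[C@H]1O` carries furan-2-yl at the same place and in this assay gives 40 nM. Compound 3 `COc1ncnc2c1c(-c1cc3ccccc3o1)cn2[C@@H]1O[C@H](CO)[C@@H](O)[C@H]1O` carries 1-benzofuran-2-yl there and in this assay gives 14500 nM. Changing this aryl group moves the numbers a great deal: an at least 500-fold lower number from compound 1 to compound 2 (2.69 log units; beyond the scatter) and a 360-fold higher number from compound 2 to compound 3 (2.56 log units; beyond the scatter), whereas an at least 1.3-fold lower number from compound 1 to compound 3 (0.13 log units; that floor lies within the scatter). Compound 2 therefore stands lowest of the two numbers, with compound 3 nearest, while the remaining value is a limit.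

Compound 4 `COc1nc(N)nc2c1c(-c1ccco1)cn2[C@@H]1O[C@H](CO)[C@@H](O)[C@H]1O` keeps the furan-2-yl group and differs from compound 2 in one place only: amino in place of hydrogen on an aromatic carbon. For the measured compounds named here, none of the measured steps touches this part of the core; all three change the aryl group, so they do not show how this assay responds to a change here. Because compound 2 gives 40 nM and the furan-2-yl group is retained, compound 4 is expected at 80 nM, with a range from 15 nM to 400 nM. This estimate means a 2.0-fold higher number from compound 2 to compound 4 (0.30 log units; within the scatter), which is expected to be a small step that may lie within the scatter.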

Compound 4, half-maximal inhibitory concentration: > 20000 nM
Compound 4 gave a limit, no number; the forecaster's own chance of this, stated with the estimate: 5%; at least 250-fold (2.39 log units) between middle value and limit.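

The earlier compounds shown here changed only the aryl group, so they said nothing about the carbon between two ring nitrogen atoms. In this assay, amino in place of hydrogen on that carbon gives an at least 500-fold higher number from compound 2 to compound 4 (2.69 log units; beyond the scatter), which shows that this position strongly affects the read-out and that keeping the furan-2-yl group does not by itself preserve the low number of compound 2. Compound 4 gives a limit of the assay and not a number, so the step has a floor but no known upper end, and the value is one that this small set has already reached: the limit of > 20000 nM in this assay, at which 2 of the 4 values shown sit.

The compounds shown leave open whether this large step belongs to amino specifically or would follow from any group on this carbon, a question that a methyl group, a chlorine atom or a methylamino group there could help to answer. From the compounds shown here alone, it also remains open whether a smaller change at this position could keep the number low, and whether the methoxy group on the same ring matters to the outcome, as a hydroxy group or an ethoxy group in its place could show.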